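Shortening the amide-borne ring amine in the sulfonamide series

This account rests on a few compounds, and the source may have more. Where it says the series, first, only, none or still open, it means among the compounds named here.

Measured so far in an assay on U2OS cells for inhibition of secreted frizzled-related protein 1 (Homo sapiens), read by a luciferase reporter, with a stated time of 18 h; on this read-out higher numbers stand for an effect only at larger amounts of compound and lower numbers for an effect already at smaller amounts:
compound 1 `CC(C)(O)CCN1CCC(NS(=O)(=O)c2cc(S(=O)(=O)c3ccccc3)ccc2C(F)(F)F)CC1` — 630 nM
compound 2 `O=C(CC1CCNCC1)N1CCC(NS(=O)(=O)c2cc(S(=O)(=O)c3ccccc3)ccc2C(F)(F)F)CC1` — 210 nM

In this assay compound 2 stands lowest of the two numbers, with a 3.0-fold lower number from compound 1 to compound 2 (0.48 log units; beyond the scatter), a modest step beyond the scatter.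

Compound 3 `O=C([C@@H]1CCNC1)N1CCC(NS(=O)(=O)c2cc(S(=O)(=O)c3ccccc3)ccc2C(F)(F)F)CC1` is not yet measured. It differs from compound 2 by pyrrolidin-3-yl in place of (piperidin-4-yl)methyl on a carbonyl carbon. Among the measured compounds shown here, the only measured step, from compound 1 to compound 2, introduced the ring amine on the carbonyl in the first place; no measured pair shows what shrinking that ring and dropping the linking carbon does. The ring amine and the carbonyl stay, so the change is expected to cost little, and the estimated step is a 1.4-fold higher number from compound 2 to compound 3 (0.15 log units; within the scatter), within or at the edge of the scatter. For compound 3 the expected value in this assay is 300 nM, with a range of 120 nM to 800 nM.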

Compound 3, half-maximal effective concentration in the secreted frizzled-related protein 1 assay: 380 nM
The estimate for compound 3 lay 1.3-fold (0.10 log units) below the measured number, and the stated range covers the measured number.
By their numbers in the secreted frizzled-related protein 1 assay, from the lowest: compounds 2, 3 and 1 (each within the scatter of the next, the first and the last beyond it).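

In the secreted frizzled-related protein 1 assay, pyrrolidin-3-yl on the carbonyl carbon gives a 1.8-fold higher number from compound 2 to compound 3 (0.26 log units; within the scatter), so the smaller ring keeps this read-out within the scatter of the (piperidin-4-yl)methyl group. The same read-out gives a 1.7-fold lower number from compound 1 to compound 3 (0.22 log units; within the scatter), which means that compound 3, unlike compound 2, cannot be told apart from the 3-hydroxy-3-methylbutyl compound. The change does register in a physicochemical assay for solubility (a lower number here means a less soluble compound, a higher number a more soluble compound), where compound 2 gives 100000 nM and compound 3 gives 12500 nM. The pair separates clearly: the measured solubility of compound 2, 100000 nM, and of compound 3, 12500 nM, an 8.0-fold lower number (0.90 log units; beyond the scatter)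

Compound 3 alters ring size, the linking carbon and the defined stereocentre at once, so the compounds shown do not say which of these goes with the solubility drop. A (piperidin-4-yl)carbonyl or (pyrrolidin-3-yl)methyl group on the same carbonyl carbon would separate ring size from the linking carbon, and the opposite pyrrolidin-3-yl enantiomer would isolate the stereocentre.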